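Working notes: tert-butyl in place of methyl, compound 3

The compounds below may be only part of what the source reports. "The series", "measured", "known", "first", "only" and "open" are said of these compounds alone.

For the measured compounds named here, compound 2 `Cc1ccc(Oc2c(/C=N/OCc3snnc3C)c(C)nn2C)cc1` is the only member of the series with a number in a functional assay on SGC-7901 cells (Homo sapiens) for inhibition, read by MTT assay, with a stated time of 48 h; a higher number here means a weaker inhibitor, a lower number a stronger inhibitor: compound 2 gives 12800 nM. Compound 1 `Cc1nnsc1CO/N=C/c1c(C)nn(C)c1Oc1ccc(I)cc1` reports > 50000 nM in this assay, which is a limit and not a number. Going by the values given here, the single measured step is an at least 3.9-fold lower number from compound 1 to compound 2 (0.59 log units; beyond the scatter); it is known only as a bound because of the limit of > 50000 nM in this assay, at which 1 of the 2 values shown sits.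

Compound 3 `Cc1nnsc1CO/N=C/c1c(C)nn(C)c1Oc1ccc(C(C)(C)C)cc1` differs from compound 2 by tert-butyl in place of methyl on an aromatic carbon. Among the compounds with values here, the step from compound 1 to compound 2 concerns the same aromatic carbon and is the only measured step that bears on this change, but it compares iodo with methyl and says nothing about what a tert-butyl in place of methyl does. No direction is therefore indicated, and compound 2 stands far from the limit, so a number is expected. The step from compound 2 to compound 3 in this assay is expected to be small, a 1.2-fold higher number from compound 2 to compound 3 (0.07 log units; within the scatter), with the direction open. For compound 3 the estimate is 15000 nM, expected between 5000 nM and 45000 nM.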

Compound 3, half-maximal inhibitory concentration: > 50000 nM
Compound 3: a limit, no number (the forecaster's own chance of this, stated with the estimate: 20%); middle value at least 3.3-fold (0.52 log units) from the limit.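

At this aromatic carbon, this assay now shows that methyl cannot be replaced by tert-butyl without a measurable loss: an at least 3.9-fold higher number from compound 2 to compound 3 (0.59 log units; beyond the scatter). Compound 3 gives > 50000 nM, which is a limit and not a number, and the step is therefore known only as a bound: the limit of > 50000 nM in this assay, at which 2 of the 3 values shown sit. Methyl is now the only one of the three groups at this carbon that gives a number, while iodo and tert-butyl both end at limits, and the step between compound 1 and compound 3 cannot be read.

As far as these compounds go, whether another group at this carbon, such as ethyl, isopropyl, methoxy, an amine or a carboxylic acid, would keep a number in this assay, or give a lower one than methyl in compound 2, stays open. From the compounds shown here alone, how far compound 1 and compound 3 lie beyond the limit also stays open, as does whether a change elsewhere on the shared core would bring either of them back to a readable number.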